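The compounds below may be only part of what the source reports. "The series", "measured", "known", "first", "only" and "open" are said of these compounds alone.

In a functional assay on HeLa cells (Homo sapiens) for cytotoxicity, read by MTT assay, with a stated time of 48 h (on this read-out higher numbers stand for weaker inhibition and lower numbers for stronger inhibition), compound 1 `CCOC(=O)[C@]1(C(=O)Nc2ccccc2)C[C@@H]1c1cc(OC)c(OC)c(OC)c1` gives > 100000 nM, which is a limit of the assay. Compound 2 `CCOC(=O)[C@]1(C(=O)Nc2ccccc2Cl)C[C@@H]1c1cc(OC)c(OC)c(OC)c1` gives > 100000 nM, also a limit, so it has no numeric position. Chloro in place of hydrogen on an aromatic carbon yields a step that the two limits leave unreadable from compound 1 to compound 2 and sets no size. Compound 4 `CCOC(=O)[C@]1(C(=O)NCc2ccc(C)cc2)C[C@@H]1c1cc(OC)c(OC)c(OC)c1` carries 4-methylbenzyl in place of 2-chlorophenyl on an amide-type nitrogen. The closest evidence is compound 3 `CCOC(=O)C1(C(=O)NCc2ccc(C)cc2)CC1c1cc(OC)c(OC)c(OC)c1`, the same structure without defined stereochemistry, which gives 33200 nM; 25600 nM (2 entries) in this assay. Compound 4 is therefore expected to sit near compound 3, although a single stereoisomer may differ from it. The expected result is an at least 3.4-fold lower number from compound 2 to compound 4 (0.53 log units; beyond the scatter), toward stronger inhibition. Compound 4 is estimated at 29000 nM, with an expected range of 12000 nM to 70000 nM.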

Compound 4, half-maximal inhibitory concentration: > 100000 nM
Compound 4: only a limit was reported; the forecaster's own chance of this, stated with the estimate: 20%; at least 3.4-fold (0.53 log units) between middle value and limit.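

No step can be read among compound 1, compound 2 and compound 4 in this assay, since all three stand at a limit: the limit of > 100000 nM in this assay, at which 3 of the 4 values shown sit.

As far as these compounds go, how compound 4 relates to compound 3 stays open, as does the ranking of the groups on the amide-type nitrogen: the fact that one of compounds 3 and 4 is drawn with a defined configuration and the other without, at the place where they differ.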